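Chlorophenyl for dimethoxyphenyl on the core of compound 3

The source may report more compounds than this note shows. Statements on the series, on what has been measured and on what is new or still open speak of the compounds shown alone.

Three compounds carry numbers in a functional assay on U-87MG ATCC cells for antiproliferative activity against U-87 MG (Homo sapiens), read by MTT assay, with a stated time of 48 h, tested at 100 uM; a higher number here means a weaker effect of the compound at the concentration tested, a lower number a stronger effect. Compound 1 `Cc1nc(-c2ccc(Cl)cc2)sc1C(=O)CSc1nc(N)c(C#N)c(-c2ccc(Cl)cc2)n1` gives 1.65%. Compound 2 `COc1ccc(-c2nc(SCC(=O)c3sc(-c4ccccc4)nc3C)[nH]c(=O)c2C#N)cc1OC` gives 6.48%. Compound 3 `COc1ccc(-c2nc(SCC(=O)c3sc(-c4ccc(Cl)cc4)nc3C)[nH]c(=O)c2C#N)cc1OC` gives 18.7%, the highest of the three, beyond the scatter from both. Within the data shown here, the only measured step, a number 12.2 percentage points higher from compound 2 to compound 3 (beyond the scatter), concerns a different aromatic carbon than the change now considered, so no measured step bears directly on it. Compound 4 `Cc1nc(-c2ccc(Cl)cc2)sc1C(=O)CSc1nc(-c2ccc(Cl)cc2)c(C#N)c(=O)[nH]1` differs from compound 3 by 4-chlorophenyl in place of 3,4-dimethoxyphenyl on an aromatic carbon. Compound 1 shows that a molecule bearing two 4-chlorophenyl groups can give a low number, but its core is not the same. The expected step is therefore modest and downward, a number 8.7 percentage points lower from compound 3 to compound 4 (within the scatter), with wide uncertainty. Compound 4 is estimated at 10%, between 0% and 30%.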

Compound 4, a percentage reported as activity, at one concentration (the size of the read-out at that concentration, not a potency): 12.8%
The estimate for compound 4 lay 2.8 percentage points below the measured number, within the range that was stated.
By their numbers in this assay, from the lowest: compounds 1, 2, 4 and 3 (each within the scatter of the next, the first and the last beyond it).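

In this assay, 4-chlorophenyl in place of 3,4-dimethoxyphenyl on the aromatic carbon next to the ring nitrogen gives a number 5.9 percentage points lower from compound 3 to compound 4 (within the scatter) and so does not separate these two groups at this position. Unlike the earlier chloro step on a different aromatic carbon, this first step read at this position stays inside the scatter. No measurement shown here accounts for the result.

Only these two substituted phenyl groups are compared at this position. Going by these compounds, whether a phenyl bearing a carboxylic acid, or a longer alkyl chain, would give a different number stays open.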